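Removing the boron-bearing group from compound 1

A few compounds are considered here, and "the series" means these few. Any claim that something is new, unique, unknown or untested is made for them only; others in the source may bear on it.

In a functional assay on DU-145 cells (Homo sapiens) for inhibition (a lower number here means a stronger inhibitor, a higher number a weaker inhibitor), compound 1 `CCOc1ccc(Br)cc1-c1cc(Nc2ccc(B(O)O)cc2)nc(N)n1` gives 500 nM as its half-maximal inhibitory concentration. Compound 3 `CCOc1ccc(Cl)cc1-c1cc(Nc2ccc3c[nH]nc3c2)nc(N)n1` gives 200 nM in the same test, which leaves compound 1 with the higher of the two numbers, by a gap beyond the scatter. Compound 2 `Cc1ccc(F)cc1-c1cc(Nc2ccc(Cl)cc2)nc(N)n1` returns only a limit, > 1000 nM, and no number.

Compound 4 `CCOc1ccc(Br)cc1-c1cc(Nc2ccccc2)nc(N)n1` has not yet been measured. It departs from compound 1 in a single place: a hydrogen atom in place of a group of 3 heavy atoms (1 boron, 2 oxygen; no ring), on an aromatic carbon. The change puts a hydrogen atom on an aromatic carbon of a six-membered aromatic ring of carbon only, para to a large group, where the group of 3 heavy atoms stood.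

Among the measured compounds shown here, no measured pair of compounds differs in one place only, so the guide is thin. Compounds 1, 2 and 3 differ from one another at more than one site. In this assay a modest rise in the number is expected, meaning weaker inhibition, and it may not go far beyond the scatter. A result reported only as a limit is also possible, given the limit of > 1000 nM in this assay, at which 1 of the 3 values shown sits, in this test. The expected change is a 1.6-fold higher number from compound 1 to compound 4 (0.20 log units; within the scatter) as an estimate. For compound 4 the estimated value is 800 nM, within an expected range of 300 nM to 2000 nM.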

Compound 4, half-maximal inhibitory concentration: > 1000 nM
Compound 4 ended at the assay's limit (the forecaster's own chance of this, stated with the estimate: 35%); at least 1.2-fold (0.09 log units) between middle value and limit.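

Among the compounds shown here, this is the first single-site change that can be read, and it falls on the aromatic carbon that carries the boron-bearing group of compound 1: in this assay, putting a hydrogen atom there gives an at least 2.0-fold higher number from compound 1 to compound 4 (0.30 log units; that floor lies within the scatter). Compound 4 gives > 1000 nM, which is a limit of the assay and not a number, so the step has a floor but no known size, and the true loss could be small or much larger. What the pair does show is that, on this core, the group of 3 heavy atoms goes with a number that can be read in this test, whereas the bare ring gives a result that joins the other one already at the ceiling: the limit of > 1000 nM in this assay, at which 2 of the 4 values shown sit.

The compounds shown do not tell whether this place favours the boron-bearing group in particular, or whether a carboxylic acid, an amine or a hydroxyl group on the same aromatic carbon would also keep a readable number. They also leave open how far compound 4 lies past the limit, and compound 3 cannot help here, as it differs from compound 1 in more than one place.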